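From Isopropyl to sec-Butyl: One Added Methyl

The source may report more compounds than this note shows. Statements on the series, on what has been measured and on what is new or still open speak of the compounds shown alone.

Compound 2 `CC(C)Sc1nc(O)cc(C(C)c2ccccc2)n1` gives > 200000 nM in a functional assay on MT4 cells (Homo sapiens) for cytotoxicity (on this read-out lower numbers stand for higher toxicity in this test and higher numbers for lower toxicity in this test), which is a limit and not a number. Compound 1 `O=c1cc(Cc2c(F)cccc2F)nc(SC2CCCC2)[nH]1` gives > 200000 nM, also a limit. Compound 3 `CCC(c1ccccc1)c1cc(O)nc(SC(C)C)n1` gives > 200000 nM, again a limit. Compound 4 `CCC(C)Sc1nc(O)cc(C(C)c2ccccc2)n1` turns the isopropyl of compound 2 into sec-butyl, a methyl in place of hydrogen on a saturated chain carbon, two bonds along the chain from a sulfur. The nearest measured change is a step that the two limits leave unreadable from compound 2 to compound 3, where the methyl sits on a different chain carbon. Among the measured compounds shown here, the only other guide is the limit of > 200000 nM in this assay, at which 3 of the 3 values shown sit. The step expected in this assay is a number no higher from compound 2 to compound 4 (the limit leaves the size open), with none beyond the scatter and no direction foreseen. Compound 4 is estimated at 200000 nM, with an expected range from 100000 nM to 400000 nM.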

Compound 4, half-maximal cytotoxic concentration: 200000 nM
Estimate against measurement, compound 4: no gap at the digits printed; the range from low to high includes it.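

In this assay, among the compounds shown here, compound 4 gives 200000 nM, the first actual number rather than a limit, so a compound carrying the (sec-butyl)sulfanyl group now has a measured value. Compound 2 gives > 200000 nM, which is a limit, so the size of the step from isopropyl to sec-butyl cannot be read. In this assay the change from isopropyl to sec-butyl gives a number no higher from compound 2 to compound 4 (the limit leaves the size open) and nothing firmer. The information from this read-out remains thin: the limit of > 200000 nM in this assay, at which 3 of the 4 values shown sit.

On these data alone, whether a longer chain or an amine in place of the sec-butyl would change the value in this assay stays open. Also open, as far as these compounds go, is whether any change at this position can produce a step of readable size.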